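A few compounds are considered here, and "the series" means these few. Any claim that something is new, unique, unknown or untested is made for them only; others in the source may bear on it.

Measured compounds:
Compound 1, `Cc1cccc(-c2nc3cc(-c4nc5cc(C#N)ccc5[nH]4)ccc3[nH]2)c1`: 860 nM
Compound 2, `N#Cc1ccc2[nH]c(-c3ccc4[nH]c(-c5cccc6ccccc56)nc4c3)nc2c1`: 650 nM

Among the measured compounds shown here, in a functional assay on RPMI 8402 cells (Homo sapiens) for cytotoxicity (a lower number here means a stronger inhibitor, a higher number a weaker inhibitor), compound 2 holds the lowest of the two numbers so far, but its only neighbour is compound 1, and the step of a 1.3-fold lower number from compound 1 to compound 2 (0.12 log units; within the scatter) lies within the scatter, so the two compounds cannot be set apart on these measurements.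

Compound 3, `CN1CCN(c2ccc3[nH]c(-c4ccc5[nH]c(-c6cccc7ccccc67)nc5c4)nc3c2)CC1`, has not yet been measured. It differs from compound 2 in one place: 4-methylpiperazin-1-yl in place of cyano on an aromatic carbon.

For the measured compounds named here, the single measured step, from compound 1 to compound 2, exchanges 3-methylphenyl for naphthalen-1-yl and leaves the cyano group untouched; it therefore says nothing about what replacing cyano with 4-methylpiperazin-1-yl does. Going by the values given here, no measured pair shows the effect of this change. In the absence of any bearing step, the expectation for compound 3 is a step of a 1.1-fold higher number from compound 2 to compound 3 (0.03 log units; within the scatter) that stays close to the value of compound 2, with a wide range to reflect the lack of information. Compound 3 is therefore estimated at 700 nM in this assay, with a range from 200 nM to 2500 nM.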

Compound 3, half-maximal inhibitory concentration: 330 nM
Beside the measured number, compound 3's estimate is 2.1-fold (0.33 log units) above it; the measured number falls inside the stated range.
By their numbers in this assay, from the lowest: compounds 3, 2 and 1 (each within the scatter of the next, the first and the last beyond it).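

Among the compounds shown here, with compound 3 the cyano group itself is exchanged for the first time, since compound 1 and compound 2 both carry it and their step concerned only the other end of the molecule. In this assay the group without a ring gives way to 4-methylpiperazin-1-yl, with its six-membered non-aromatic ring holding 2 hetero atoms, on an aromatic carbon of the fused system, and the result is a 2.0-fold lower number from compound 2 to compound 3 (0.29 log units; within the scatter): the printed step lies within the scatter, so the two compounds cannot be set apart, and this position accepts the much larger group with no change that these measurements can resolve. Nothing measured alongside these numbers gives a reason for this outcome.

The compounds shown leave open how other groups would fare at this position, for example a simple primary amine, a carboxylic acid, a morpholine ring or an open-chain amine on a longer chain. They also leave open whether 4-methylpiperazin-1-yl would give the same result with 3-methylphenyl in place of naphthalen-1-yl at the other end of the core.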